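Halogen Swap at the Aromatic Position: Bromo to Fluoro

The compounds below may be only part of what the source reports. "The series", "measured", "known", "first", "only" and "open" are said of these compounds alone.

Three compounds share one core and differ only in a single substituent on an aromatic carbon. Compound 1 `COC(=O)[C@@]1(C)CCC=C2[C@@H]1CC[C@@H](C)[C@]2(C)Cc1c[nH]c2ccccc12` carries hydrogen there; in a functional assay on HBL-100 cells (Homo sapiens) for inhibition, read by sulforhodamine B assay, with a stated time of 48 h (a lower number here means a stronger inhibitor of growth, a higher number a weaker inhibitor of growth), compound 1 gives 4500 nM. Compound 2 `COC(=O)[C@@]1(C)CCC=C2[C@@H]1CC[C@@H](C)[C@]2(C)Cc1c[nH]c2ccc(Br)cc12` carries bromo at that position, and in this assay compound 2 gives 16000 nM. Compound 3 `COC(=O)[C@@]1(C)CCC=C2[C@@H]1CC[C@@H](C)[C@]2(C)Cc1c[nH]c2ccc(Cl)cc12` carries chloro, and in this assay compound 3 gives 17000 nM. Among these three numbers compound 2 stands second highest: its nearest neighbour is compound 3, separated by a 1.1-fold higher number from compound 2 to compound 3 (0.03 log units; within the scatter), which lies within the scatter, while the step of a 3.6-fold higher number from compound 1 to compound 2 (0.55 log units; beyond the scatter) and the matching step a 3.8-fold higher number from compound 1 to compound 3 (0.58 log units; beyond the scatter) are both beyond the scatter and of similar size.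

Compound 4 `COC(=O)[C@@]1(C)CCC=C2[C@@H]1CC[C@@H](C)[C@]2(C)Cc1c[nH]c2ccc(F)cc12` has not yet been measured. It differs from compound 2 by fluoro in place of bromo on an aromatic carbon. The two halogen steps from compound 1 bear on this change, and they show that chloro and bromo behave alike here; fluoro is a third halogen at the same position, and no measured data separate it from the other two. The expected step of a 1.5-fold lower number from compound 2 to compound 4 (0.16 log units; within the scatter) is therefore small, with a slight lean toward a lower number since compound 1 with hydrogen gives 4500 nM. Compound 4 is estimated at 11000 nM, with a range from 5000 nM to 25000 nM.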

Compound 4, concentration for 50% growth inhibition: 4800 nM
Compound 4: the middle estimate sits 2.3-fold (0.36 log units) above what was measured; the measured number lies below the stated range.
By their numbers in this assay, from the lowest: compounds 1 and 4 (each within the scatter of the next); then compounds 2 and 3 (each within the scatter of the next).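

In this assay the halogens at this position do not act as one group: the change to fluoro gives a 3.3-fold lower number from compound 2 to compound 4 (0.52 log units; beyond the scatter) and a 3.5-fold lower number from compound 3 to compound 4 (0.55 log units; beyond the scatter) and so separates fluoro from both bromo and chloro. Set against hydrogen, fluoro gives a 1.1-fold higher number from compound 1 to compound 4 (0.03 log units; within the scatter) and cannot be told apart from it on this read-out, so the weaker growth inhibition seen with bromo and chloro does not extend to every halogen in this set. Nothing in the data shown explains why fluoro parts from the other two halogens here.

From the compounds shown here alone, what remains open is how other groups at this position would fall, for instance whether a methoxy group, a nitrile or an amine would sit with hydrogen and fluoro or with bromo and chloro. Also open, going by these compounds, is whether the same split between halogens would hold on a changed core, such as one bearing a carboxylic acid in place of the methyl ester, or on other cell lines.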